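Working notes: from compound 2 to compound 4

The compounds below may be only part of what the source reports. "The series", "measured", "known", "first", "only" and "open" are said of these compounds alone.

Measured so far:
- compound 1 `COC(=O)C1=C(C)NC(c2nccs2)=NC1(C)c1ccc(Cl)cc1`: 85 mL/min/kg
- compound 2 `COC(=O)C1=C(CN2CCCCC2)NC(c2nccs2)=NC1(C)c1ccc(F)cc1`: 88 mL/min/kg
- compound 3 `COC(=O)C1=C(CN2CCNC(=O)C2)NC(c2nccs2)=NC1(C)c1ccc(F)cc1`: 81 mL/min/kg

In an ADME assay on microsomes from liver (Mus musculus) for metabolic stability, read by LC-MS, using NADPH, with stated times of 10 min and 30 min, tested at 1 uM (on this read-out lower numbers stand for slow clearance and higher numbers for fast clearance), compound 2 gives 88 mL/min/kg. This lies within the scatter of the other two numbers, compound 1 at 85 mL/min/kg and compound 3 at 81 mL/min/kg, so the three compounds cannot be ranked.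

The next compound is compound 4 `COC(=O)C1=C(CN2CCC(O)C2)NC(c2nccs2)=NC1(C)c1ccc(F)cc1`, which carries one change from compound 2: 3-hydroxypyrrolidin-1-yl in place of piperidin-1-yl on a saturated chain carbon bound to a double-bonded ring carbon. In words, 3-hydroxypyrrolidin-1-yl stands in place of piperidin-1-yl on a saturated chain carbon bound to a double-bonded ring carbon.

Among the compounds with values here, only one measured step bears on this place: a 1.1-fold lower number from compound 2 to compound 3 (0.04 log units; within the scatter). It also replaces piperidin-1-yl and stays within the scatter. Within the data shown here, compound 1 differs from compound 2 in more than one place and offers no single step. Among the measured compounds shown here, no measured compound carries 3-hydroxypyrrolidin-1-yl, so the evidence is thin.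

No step beyond the scatter is therefore expected in this assay. The expected step is a 1.1-fold lower number from compound 2 to compound 4 (0.04 log units; within the scatter). For compound 4 the estimated value is 80 mL/min/kg, with an expected range of 52 mL/min/kg to 98 mL/min/kg.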

Compound 4, clearance: 83 mL/min/kg
Beside the measured number, compound 4's estimate is 1.0-fold (0.02 log units) below it, within the range that was stated.
By their numbers in this assay, from the lowest: compounds 3, 4, 1 and 2 (each within the scatter of the next).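

At the saturated chain carbon bound to a double-bonded ring carbon, this assay now holds a second replacement of piperidin-1-yl, with a 1.1-fold lower number from compound 2 to compound 4 (0.03 log units; within the scatter) for a five-membered non-aromatic ring carrying a hydroxyl group. The two replacing groups can also be read against each other, with a 1.0-fold higher number from compound 3 to compound 4 (0.01 log units; within the scatter) as their step, so neither ring size nor the swap of 3-oxopiperazin-1-yl for 3-hydroxypyrrolidin-1-yl separates compound 2, compound 3 and compound 4 on this read-out, and all three steps at this place remain within the scatter. No measurement at hand offers an explanation for this flat picture.

From the compounds shown here alone, it remains open whether any group at this place can give a step beyond the scatter, for example a carboxylic acid on the ring of the amine, a morpholin-4-yl group, or a longer chain in place of the single saturated carbon that links the amine to the core. The single steps shown also concern this place alone, so the effect of changes elsewhere on the shared core stays unread.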